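Swapping the benzyl for a pyrazinyl ring on the piperazine

The compounds below may be only part of what the source reports. "The series", "measured", "known", "first", "only" and "open" are said of these compounds alone.

Measured compounds:
- compound 1 `Nc1ccccc1NC(=O)c1ccc(CSC(=S)N2CCN(C3CCCCC3)CC2)cc1` — 89.9%
- compound 2 `Nc1ccccc1NC(=O)c1ccc(CSC(=S)N2CCN(Cc3ccncc3)CC2)cc1` — 89.5%
- compound 3 `Nc1ccccc1NC(=O)c1ccc(CSC(=S)N2CCN(Cc3ccccc3)CC2)cc1` — 29.3%

All three were tested in a functional assay on A-375 cells (Homo sapiens) for antiproliferative activity, read by CCK-8 assay, with a stated time of 72 h, tested at 8 uM; on this read-out higher numbers stand for a stronger effect at the one concentration tested and lower numbers for a weaker effect. Compound 3 stands lowest of the three numbers: the step of a number 60.6 percentage points lower from compound 1 to compound 3 (beyond the scatter) and the step of a number 60.2 percentage points lower from compound 2 to compound 3 (beyond the scatter) are both large and beyond the scatter, while compound 1 and compound 2 sit within the scatter of each other, as a number 0.4 percentage points lower from compound 1 to compound 2 (within the scatter) shows.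

Compound 4 `Nc1ccccc1NC(=O)c1ccc(CSC(=S)N2CCN(c3cnccn3)CC2)cc1` differs from compound 3 in one place: pyrazin-2-yl in place of benzyl on an amine nitrogen in a ring. The two steps that bear on it are those landing on compound 3, a number 60.6 percentage points lower from compound 1 to compound 3 (beyond the scatter) and a number 60.2 percentage points lower from compound 2 to compound 3 (beyond the scatter), which show that replacing the benzyl by either of the other two groups goes with a large gain. Compound 2 carries a ring with a nitrogen atom and gives 89.5%, which suggests an aromatic ring with nitrogen is tolerated. Among the compounds with values here, no measured compound has an aromatic ring bound directly to the ring nitrogen, so the direct attachment in compound 4 is untested.

Compound 4 is therefore expected to climb by a number 35.7 percentage points higher from compound 3 to compound 4 (beyond the scatter), though with a broad range. The estimate for compound 4 is 65%, between 30% and 92%.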

Compound 4, a percentage reported as inhibition, at one concentration (the size of the read-out at that concentration, not a potency): 85.8%
Estimate against measurement, compound 4: 20.8 percentage points below; low and high end bracket the measured number.
By their numbers in this assay, from the lowest: compound 3; then compounds 4, 2 and 1 (each within the scatter of the next).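

In this assay the pyrazin-2-yl group, an aromatic ring bound directly to the ring nitrogen, proves compatible with high inhibition at this position: a number 56.5 percentage points higher from compound 3 to compound 4 (beyond the scatter) marks a large gain over benzyl, while a number 3.7 percentage points lower from compound 2 to compound 4 (within the scatter) and a number 4.1 percentage points lower from compound 1 to compound 4 (within the scatter) both stay within the scatter. Among these four compounds, compound 3 with its benzyl is thus the only outlier, and compounds 1, 2 and 4 cannot be told apart, whether the group is saturated, linked through a chain carbon or attached directly. Nothing measured here gives a reason for the gap between benzyl and the other three groups.

A plain phenyl ring bound directly to the ring nitrogen would show whether direct attachment alone matters, or whether the ring nitrogens are also needed. As far as these compounds go, with one concentration, whether compounds 1, 2 and 4 would differ in the strength of their effect at other concentrations also remains open.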